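Quinazoline series: 6-methoxypyridin-3-yl anilide replacement, compound 4

The source may hold more compounds than are shown below. What is called first, only, known or untested is meant among the compounds shown, and "the series" means these compounds.

Measured so far:
Compound 1 `CCS(=O)(=O)Nc1cc(-c2ccc3ncnc(Nc4ccc(OC)c(OC)c4)c3c2)cnc1OC` gives 4360 nM in a functional assay on HCT-116 cells (Homo sapiens) for cytotoxicity, read by sulforhodamine B assay, with a stated time of 72 h; on this read-out lower numbers stand for stronger inhibition and higher numbers for weaker inhibition.
Compound 2 `CCS(=O)(=O)Nc1cc(-c2ccc3ncnc(Nc4ccc(OC)c(Cl)c4)c3c2)cnc1OC` gives 5620 nM in this assay.
Compound 3 `CCS(=O)(=O)Nc1cc(-c2ccc3ncnc(Nc4ccc(OCc5ccc(F)cc5)c(Cl)c4)c3c2)cnc1OC` gives 5410 nM in this assay.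

Compound 2 carries the largest of the three numbers, but its gaps to the two neighbours are small: a 1.3-fold higher number from compound 1 to compound 2 (0.11 log units; within the scatter) and a 1.0-fold lower number from compound 2 to compound 3 (0.02 log units; within the scatter) both stay within the scatter, so the three compounds are indistinguishable on this read-out.

Compound 4 `CCS(=O)(=O)Nc1cc(-c2ccc3ncnc(Nc4ccc(OC)nc4)c3c2)cnc1OC` has not been measured. It differs from compound 2 by 6-methoxypyridin-3-yl in place of 3-chloro-4-methoxyphenyl on a nitrogen on an aromatic ring. Going by the values given here, no measured step touches the same position in the same way; the two steps known, the chloro-for-methoxy exchange and the 4-fluorophenyl addition on the chain carbon bound to the aromatic oxygen, both left the number within the scatter. Nothing in the series therefore points to a step beyond the scatter in this assay in either direction. For compound 4 the expected step is a 1.1-fold lower number from compound 2 to compound 4 (0.05 log units; within the scatter), and the estimate is 5000 nM, with a range of 2000 nM to 14000 nM.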

Compound 4, half-maximal inhibitory concentration: 6910 nM
Estimate against measurement, compound 4: 1.4-fold (0.14 log units) below; the measured number falls inside the stated range.
By their numbers in this assay, from the lowest: compounds 1, 3, 2 and 4 (each within the scatter of the next).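

In this assay, exchanging the whole aryl group on the nitrogen gives a 1.2-fold higher number from compound 2 to compound 4 (0.09 log units; within the scatter) and, with 3,4-dimethoxyphenyl as the group that leaves, a 1.6-fold higher number from compound 1 to compound 4 (0.20 log units; within the scatter). Unlike the earlier steps, these two replace the six-membered aromatic ring of carbon only with one bearing 1 hetero atom, and both pairs show that this exchange at the nitrogen on an aromatic ring leaves the number within the scatter, whichever of the two phenyl groups it replaces. No data are available that bear on why this read-out stays flat across the change.

Still open, going by these compounds, is whether any group at this nitrogen moves the number beyond the scatter, for instance a pyridine carrying an amine or a carboxylic acid, or a longer chain in place of the methoxy group. On these data alone, the ethanesulfonamide, the same in all four compounds, also remains untested.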